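The source may report more compounds than this note shows. Statements on the series, on what has been measured and on what is new or still open speak of the compounds shown alone.

Compound 1, `COc1ccc(-c2cnc(NC(=O)c3cccc([N+](=O)[O-])c3)n2C)cc1`, in a toxicity assay on THP-1 cells (Homo sapiens) for inhibition (a higher number here means that more compound is tolerated, a lower number that less compound is tolerated), gives > 100000 nM.
Compound 2, `Cn1cc(-c2ccccc2)nc1NC(=O)c1ccc(F)cc1`, gives > 50000 nM in this assay.
Compound 3, `Cn1c(-c2cccc([N+](=O)[O-])c2)cnc1NC(=O)c1ccc(F)cc1`, gives > 50000 nM in this assay.

None of these three readings is a number; each is a limit of the assay, meaning no toxic effect was reached up to the highest concentration tested. Compound 1 sits at the limit of > 100000 nM in this assay, at which 1 of the 3 values shown sits. Compound 2 and compound 3 sit at the limit of > 50000 nM in this assay, at which 2 of the 3 values shown sit. So compound 1 stands at the higher of the two limits seen, but as all three readings are limits, no ordering among the three compounds can be read from them, and no step between measured compounds is available.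

Compound 4, `COc1ccc(-c2cnc(NC(=O)c3cccc(C)c3)n2C)cc1`, differs from compound 1 in one place: methyl in place of nitro on an aromatic carbon. With every measured compound tolerated up to its limit, the expectation for this step in this assay is no change beyond the usual scatter. Compound 4 is therefore expected to give about 100000 nM, within 50000 nM to 200000 nM, most likely again reported only as a limit. The expected step is a number no higher from compound 1 to compound 4 (the limit leaves the size open).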

Compound 4, half-maximal cytotoxic concentration: > 100000 nM
Compound 4: no number, only a limit; the forecaster's own chance of this, stated with the estimate: 85%; the middle value sits exactly at the limit.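

Compound 4 gives > 100000 nM in this assay, which is a limit and not a number. Among the compounds shown here, compound 1 is also known only as a limit, and no step between compound 1 and compound 4 can be read. The compounds shown leave open at what concentration any of them becomes toxic to these cells.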